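This account rests on a few compounds, and the source may have more. Where it says the series, first, only, none or still open, it means among the compounds named here.

Measured compounds:
compound 1 `Cc1c(C(=O)N/N=C\c2ccccc2O)oc2cccc(O)c12`, 8350 nM
compound 2 `Cc1c(C(=O)N/N=C\c2c(O)cccc2Cl)oc2cccc(O)c12`, 18700 nM
compound 3 `Cc1c(C(=O)N/N=C\c2cccc(F)c2O)oc2cccc(O)c12`, 12700 nM

In a functional assay on PC-3 cells (Homo sapiens) for inhibition (on this read-out higher numbers stand for weaker inhibition and lower numbers for stronger inhibition), compound 1 gives the lowest of the three numbers. The nearest number is reached by a 1.5-fold higher number from compound 1 to compound 3 (0.18 log units; within the scatter), a gap within the scatter; the furthest by a 2.2-fold higher number from compound 1 to compound 2 (0.35 log units; beyond the scatter), a modest step beyond it. Compound 4 `Cc1c(C(=O)N/N=C\c2cc(Cl)ccc2O)oc2cccc(O)c12` has not been measured. It differs from compound 1 by chloro in place of hydrogen on an aromatic carbon; cut one bond further out, the change reads 2-hydroxyphenyl to 5-chloro-2-hydroxyphenyl, the chloro sitting para to the hydroxy group.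

Going by the values given here, two measured steps bear on the change, both adding a halogen to the same phenyl ring of compound 1: a 2.2-fold higher number from compound 1 to compound 2 (0.35 log units; beyond the scatter) adds a chloro and a 1.5-fold higher number from compound 1 to compound 3 (0.18 log units; within the scatter) adds a fluoro. Neither halogen sits where the chloro of compound 4 does, so they are only a guide; both point the same way, upward, and between them a 1.5-fold lower number from compound 2 to compound 3 (0.17 log units; within the scatter) is within the scatter. The expectation is therefore a small rise in this assay, at or just beyond the scatter, estimated as a 1.6-fold higher number from compound 1 to compound 4 (0.19 log units; within the scatter). Compound 4 is expected to give 13000 nM, in the range 6000 nM to 28000 nM.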

Compound 4, half-maximal inhibitory concentration: 3120 nM
The estimate for compound 4 lay 4.2-fold (0.62 log units) above the measured number; the whole stated range lies above it.
By their numbers in this assay, from the lowest: compound 4; then compounds 1, 3 and 2 (each within the scatter of the next, the first and the last beyond it).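

In this assay, chloro in place of hydrogen has no single direction on this phenyl ring: para to a hydroxy group and meta to a large group, it lowers the number (in a 2.7-fold lower number from compound 1 to compound 4 (0.43 log units; beyond the scatter)), whereas the chloro of compound 2 raises it (in a 2.2-fold higher number from compound 1 to compound 2 (0.35 log units; beyond the scatter)). Where the chloro stands therefore decides the sign of the step, as the two chloro compounds show (in a 6.0-fold lower number from compound 2 to compound 4 (0.78 log units; beyond the scatter)), and the 5-chloro-2-hydroxyphenyl group also outperforms the 3-fluoro-2-hydroxyphenyl group (in a 4.1-fold lower number from compound 3 to compound 4 (0.61 log units; beyond the scatter)). Compound 4 is thus the strongest inhibitor of the four, with its steps to all the others beyond the scatter, but nothing available explains why this position behaves differently from the other substituted positions.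

Still open, as far as these compounds go, is whether the lower number belongs to chloro specifically or to any group para to the hydroxy group, such as a fluoro, a bromo, a methoxy or an amine. Also open, from the compounds shown here alone, is whether a carboxylic acid or a longer chain at that position would keep the number low.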